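The source may hold more compounds than are shown below. What is called first, only, known or untested is meant among the compounds shown, and "the series" means these compounds.

In a functional assay on PC-3 cells (Homo sapiens) for cytotoxicity, read by MTT assay, with a stated time of 5 days (on this read-out lower numbers stand for stronger inhibition of growth and higher numbers for weaker inhibition of growth), compound 2, with the structure `O=[N+]([O-])c1ccccc1NS(=O)(=O)c1ccccc1`, gives the value 22900 nM. This is the lower of the two numbers recorded; the other belongs to compound 3, the structure `Cc1ccc(NC(=O)c2ccc(C)cc2)cc1`, which in this assay gives 26900 nM, and the gap between the two lies within the usual scatter of repeated measurements, so neither can be called the more active. A third member of the set, compound 1 with the structure `Cc1ccc(/N=C/c2ccccc2)cc1`, in this assay gives "not determined" (no result reported), so no number is available for it.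

Compound 4, with the structure `Cc1ccc(NS(=O)(=O)c2ccccc2)c([N+](=O)[O-])c1`, has not yet been measured. Compared with compound 2 it differs in one place: methyl in place of hydrogen on an aromatic carbon. Among the measured compounds shown here, no pair of measured compounds differing in a single place is available, so there is nothing to show how large a change of this kind is here. Because compound 2 gives 22900 nM and the change adds only a methyl group, the expected step from compound 2 to compound 4 is small, a 1.1-fold lower number from compound 2 to compound 4 (0.06 log units; within the scatter), in no direction beyond the scatter. Compound 4 is therefore expected to give about 20000 nM in this assay, within a range from 7000 nM to 60000 nM.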

Compound 4, concentration for 50% growth inhibition: 60300 nM
Estimate against measurement, compound 4: 3.0-fold (0.48 log units) below, outside the stated range (above it).
By their numbers in this assay, from the lowest: compounds 2 and 3 (each within the scatter of the next); then compound 4.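

In this assay, among the compounds shown here, putting a methyl in place of hydrogen gives a 2.6-fold higher number from compound 2 to compound 4 (0.42 log units; beyond the scatter), and this is the first single change in the set whose effect can be read. It shows that this aromatic carbon, meta to a nitro group and para to a large group, is not indifferent: one added carbon is enough to weaken growth inhibition beyond the scatter, although the step is only modest. Nothing measured here bears on the reason for this loss.

For the compounds shown here, with only one change at this position, it remains open whether the loss grows with size, as an ethyl group might show, or also appears with a different kind of group, such as fluorine, methoxy or an amine. As far as these compounds go, whether methyl would have the same effect at other carbons of this ring also remains open.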